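Bromo for Hydrogen on Two Related Cores

The source may hold more compounds than are shown below. What is called first, only, known or untested is meant among the compounds shown, and "the series" means these compounds.

Measured in a functional assay on A549 cells (Homo sapiens) for antiproliferative activity, read by sulforhodamine B assay, with a stated time of 48 h; on this read-out higher numbers stand for weaker inhibition and lower numbers for stronger inhibition:
- compound 1, `COc1ccc2nc(-c3ccc(N/C=C\C(=O)c4cc(OC)c(OC)c(OC)c4)cc3)sc2c1`: 12100 nM
- compound 2, `COc1cc(OC)c2sc(-c3ccc(N/C=C\C(=O)c4cc(OC)c(OC)c(OC)c4)cc3)nc2c1`: 21800 nM
- compound 3, `COc1ccc2nc(-c3ccc(N/C=C\C(=O)c4cc(OC)c(OC)c(OC)c4Br)cc3)sc2c1`: 6000 nM

Compound 1 and compound 2 share most of their structure but differ in the core; that difference between the two cores is not broken down here. Their values in this assay lie within the scatter of one another. Compound 3 carries one change relative to compound 1, (bromo in place of hydrogen on an aromatic carbon), and this gave a 2.0-fold lower number from compound 1 to compound 3 (0.30 log units; within the scatter).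

Compound 4, `COc1cc(OC)c2sc(-c3ccc(N/C=C\C(=O)c4cc(OC)c(OC)c(OC)c4Br)cc3)nc2c1`, is not yet measured. It differs from compound 2 by bromo in place of hydrogen on an aromatic carbon, the same change as from compound 1 to compound 3, at an identically described place. Going by the values given here, the step is expected to be of similar size, a 2.0-fold lower number from compound 2 to compound 4 (0.30 log units; within the scatter), resting on the single measured step of a 2.0-fold lower number from compound 1 to compound 3 (0.30 log units; within the scatter); with only one precedent, a step within the scatter is also plausible. Compound 4 is thus estimated at 11000 nM in this assay, expected between 5000 nM and 25000 nM.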

Compound 4, half-maximal inhibitory concentration: 12000 nM
Compound 4: middle estimate off by 1.1-fold (0.04 log units), on the low side, and the stated range covers the measured number.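

In this assay bromo in place of hydrogen on an aromatic carbon gave a 1.8-fold lower number from compound 2 to compound 4 (0.26 log units; within the scatter) and so matched the earlier step on the other core: the same change on two cores in this assay, a 2.0-fold lower number (0.30 log units; within the scatter) from compound 1 to compound 3 and a 1.8-fold lower number (0.26 log units; within the scatter) from compound 2 to compound 4, 1.1-fold (0.05 log units) apart, within the scatter of two such steps.

The change therefore carried over between these two cores with a step of similar size. Each step lies within the scatter on its own, so the agreement does not establish a real gain from bromo on either core, and two cores say nothing about any further core.

The compounds shown leave open whether chloro, fluoro or methyl on the same aromatic carbon would give a step of the same size. Also open, from the compounds shown here alone, is whether an amine or a carboxylic acid there would give a step beyond the scatter.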